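This account rests on a few compounds, and the source may have more. Where it says the series, first, only, none or still open, it means among the compounds named here.

Of the compounds shown here, two have so far been tested in a functional assay on MCF7 cells (Homo sapiens) for cytotoxicity, read by MTT assay, with a stated time of 72 h; on this read-out higher numbers stand for lower toxicity in this test and lower numbers for higher toxicity in this test. Compound 1 `[SeH]c1nc([SeH])c2cccnc2n1` gives 82700 nM in this assay, and compound 2 `CSc1nc(NCCCCc2ccccc2)c2ccccc2n1` gives 95900 nM in this assay. Compound 2 holds the higher of these two numbers, but its gap to compound 1 lies within the scatter, so the two results cannot be told apart. Compound 3 `CSc1nc(NCCCCCO)c2ccccc2n1` has not yet been measured. It differs from compound 2 in one place: hydroxymethyl in place of phenyl on a saturated chain carbon, four bonds along the chain from a nitrogen on an aromatic ring. Within the data shown here, no step between measured compounds resembles this change, so there is no direct guide to its size. The expected step of a 1.3-fold higher number from compound 2 to compound 3 (0.10 log units; within the scatter) is small enough to stay within the scatter, pointing to no clear shift in either direction. On that basis compound 3 is expected to give about 120000 nM in this assay, with a plausible range from 40000 nM to 300000 nM.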

Compound 3, concentration lethal to 50% of the cells: > 100000 nM
Compound 3: no number, only a limit; the forecaster's own chance of this, stated with the estimate: 30%; the middle value lies beyond the limit too.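

The result for compound 3 in this assay is a limit of the test, not a number: the limit of > 100000 nM in this assay, at which 1 of the 3 values shown sits. Hydroxymethyl in place of phenyl at this position, on a saturated chain carbon, four bonds along the chain from a nitrogen on an aromatic ring, gives an at least 1.0-fold higher number from compound 2 to compound 3 (0.01 log units; that floor lies within the scatter). So this is the first sign that a group with no ring, carrying one hydrogen-bond donor and one acceptor, can replace the aromatic ring of carbon only here with no sign of higher toxicity in this test, although the true size of the step stays unknown.

As far as these compounds go, it remains open whether any group here can clearly lower the number. An amine, a carboxylic acid or a longer chain at this place could give a measurable value, and the compounds shown say nothing about them.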